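The source may hold more compounds than are shown below. What is called first, only, known or untested is meant among the compounds shown, and "the series" means these compounds.

compound 1 `Cc1nsc2c1ncn2[C@H]1C[C@H](O)[C@@H](CO)O1`: > 100000 nM
compound 2 `CSc1nc2c(C)nsc2n1[C@H]1C[C@H](O)[C@@H](CO)O1`: > 100000 nM

In a functional assay on HFF cells (Homo sapiens) for inhibition (a lower number here means a stronger inhibitor, a higher number a weaker inhibitor), compound 1 `Cc1nsc2c1ncn2[C@H]1C[C@H](O)[C@@H](CO)O1` gives > 100000 nM, a limit of the assay rather than a number. Compound 2 `CSc1nc2c(C)nsc2n1[C@H]1C[C@H](O)[C@@H](CO)O1` likewise gives > 100000 nM in this assay, again only a limit. Both measured values sit at the limit of > 100000 nM in this assay, at which 2 of the 2 values shown sit. The step that the two limits leave unreadable from compound 1 to compound 2 is therefore unreadable, and compound 2 stands only at a limit. Compound 3 `CSc1nc2cnsc2n1[C@H]1C[C@H](O)[C@@H](CO)O1` differs from compound 2 by hydrogen in place of methyl on an aromatic carbon. No readable measured step bears on this change. Compound 3 is expected to remain at the same limit, estimated at 100000 nM with a range of 30000 nM to 300000 nM. The expected step of a number no higher from compound 2 to compound 3 (the limit leaves the size open) is thus none beyond the scatter.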

Compound 3, half-maximal inhibitory concentration: > 100000 nM
Compound 3 gave a limit, no number; the forecaster's own chance of this, stated with the estimate: 85%; the middle value sits exactly at the limit.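

No step can be read from compound 2 to compound 3, as both values are limits and not numbers: the limit of > 100000 nM in this assay, at which 3 of the 3 values shown sit.

The compounds shown leave open which change to the shared core, if any, would give a measurable inhibitory concentration.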